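Halogen swap on the aryl urea of an imidazole-phenoxy series

A few compounds are considered here, and "the series" means these few. Any claim that something is new, unique, unknown or untested is made for them only; others in the source may bear on it.

Measured compounds:
Compound 1 `O=C(Nc1ccc(Oc2ccc(-c3ncc[nH]3)cc2)cc1)Nc1ccc(Cl)c([N+](=O)[O-])c1` — 3.36%
Compound 2 `O=C(Nc1ccc(Oc2ccc(-c3ncc[nH]3)cc2)cc1)Nc1cc(C(F)(F)F)ccc1Cl` — 32.3%

Going by the values given here, in a functional assay on MDA-MB-231 cells (Homo sapiens) for inhibition, read by MTT assay and WST assay, with a stated time of 72 h, tested at 10 uM (a higher number here means more inhibition of growth at the concentration tested, a lower number less inhibition of growth), compound 2 stands highest of the two numbers, with compound 1 as its nearest neighbour, and the step of a number 28.9 percentage points higher from compound 1 to compound 2 (beyond the scatter) is the only measured comparison. Compound 3 `O=C(Nc1ccc(Oc2ccc(-c3ncc[nH]3)cc2)cc1)Nc1cc(Br)cc(C(F)(F)F)c1` differs from compound 2 by 3-bromo-5-(trifluoromethyl)phenyl in place of 2-chloro-5-(trifluoromethyl)phenyl on an amide-type nitrogen. Among the compounds with values here, no measured step exchanges one halogen for another while keeping the trifluoromethyl group, so the single step from compound 1 to compound 2 bears only loosely on it. Compound 3 is therefore expected to stay near compound 2, with a step of a number 2.3 percentage points lower from compound 2 to compound 3 (within the scatter) within the scatter, giving an estimate of 30% (range 10% to 50%).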

Compound 3, percent growth inhibition at one concentration: -13.6%
Compound 3: middle estimate off by 43.6 percentage points, on the high side, and the stated range ends above it.
By their numbers in this assay, from the lowest: compound 3; then compound 1; then compound 2.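

In this assay, the aryl group on the amide-type nitrogen proves far more sensitive than the earlier step showed: with the trifluoromethyl group kept, 3-bromo-5-(trifluoromethyl)phenyl brings a number 45.9 percentage points lower from compound 2 to compound 3 (beyond the scatter) and removes all growth inhibition. Even the weak 4-chloro-3-nitrophenyl group fares better, with a number 17 percentage points lower from compound 1 to compound 3 (beyond the scatter) on replacing it, so the trifluoromethyl group alone does not secure inhibition. Nothing measured here accounts for these steps.

This change alters both the halogen and its place on the ring, and the compounds shown do not separate the two. From the compounds shown here alone, how an amine or a carboxylic acid on this ring would fare also remains open.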